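Cytotoxicity limits across three aryl analogues and a fourth

This account rests on a few compounds, and the source may have more. Where it says the series, first, only, none or still open, it means among the compounds named here.

The shared core carries an aryl amine whose single substituent is varied. Compound 1 `COc1ccc(NCCNc2ccnc3cc(Cl)ccc23)cc1` bears methoxy; in a toxicity assay on Huh-7 cells (Homo sapiens) for cytotoxicity, read by MTT assay, with a stated time of 72 h (a higher number here means that more compound is tolerated, a lower number that less compound is tolerated), compound 1 gives only a limit, > 100 ug/mL. Compound 2 `Fc1ccc(NCCNc2ccnc3cc(Cl)ccc23)cc1` carries fluoro in place of methoxy; in this assay compound 2 likewise reaches only a limit, > 100 ug/mL. Compound 3 `Clc1ccc(NCCNc2ccnc3cc(Cl)ccc23)cc1` carries chloro; in this assay compound 3 also stops at a limit, > 100 ug/mL. The three steps between them, a step that the two limits leave unreadable from compound 1 to compound 2, a step that the two limits leave unreadable from compound 1 to compound 3 and a step that the two limits leave unreadable from compound 2 to compound 3, are therefore unreadable: every value sits at the same point, (the limit of > 100 ug/mL in this assay, at which 3 of the 3 values shown sit), and nothing separates them. Compound 3 thus stands at the limit together with the other two, neither distinguished from them nor ranked among them.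

Compound 4 `Cc1ccc(NCCNc2ccnc3cc(Cl)ccc23)cc1` follows from compound 3 by methyl in place of chloro on an aromatic carbon. The three measured steps each exchanged one small substituent for another on the same aromatic carbon and none of them brought a value below the limit. Given that compound 1, compound 2 and compound 3 all sit at the limit of > 100 ug/mL in this assay, at which 3 of the 3 values shown sit, the step that the limit leaves unreadable from compound 3 to compound 4 is expected to be none beyond the scatter, most probably another reading at the limit. The estimate for compound 4 in this assay is 150 ug/mL, with a range from 80 ug/mL to 400 ug/mL.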

Compound 4, half-maximal cytotoxic concentration: > 100 ug/mL
Compound 4 was reported as a limit (the forecaster's own chance of this, stated with the estimate: 85%); the middle value does not contradict the limit.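

In this assay compound 4 gives > 100 ug/mL, a limit and not a number. No new step can be read from compound 4 to compound 1, compound 2 or compound 3, as all four share one point: the limit of > 100 ug/mL in this assay, at which 4 of the 4 values shown sit. Still open is whether any aryl substituent among these four separates them in this assay, since none has a numerical value.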